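Methyl on a ring oxygen across two related cores

A few compounds are considered here, and "the series" means these few. Any claim that something is new, unique, unknown or untested is made for them only; others in the source may bear on it.

Measured compounds: compound 1 `O=C(Nc1cccc(-n2cc(-c3ccncc3)c(-c3cc(O)cc(Cl)c3)n2)c1)Nc1ccc(Cl)c(Cl)c1` with 4.11%; compound 2 `COc1cc(Cl)cc(-c2nn(-c3cccc(NC(=O)Nc4ccc(Cl)c(Cl)c4)c3)cc2-c2ccncc2)c1` with 5.73%; compound 3 `O=C(Nc1cccc(-n2cc(-c3ccncc3)c(-c3cc(O)cc(Cl)c3)n2)c1)c1cc(C(F)(F)F)cc(C(F)(F)F)c1` with 26.9%, all in a functional assay on CCRF-CEM cells (Homo sapiens) for inhibition, read by sulforhodamine B assay, with a stated time of 48 h, tested at 10 uM; a lower number here means a stronger effect, a higher number a weaker effect of the compound at the concentration tested.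

Compound 1 and compound 2 share one core; compound 3 and the unmeasured compound 4 `COc1cc(Cl)cc(-c2nn(-c3cccc(NC(=O)c4cc(C(F)(F)F)cc(C(F)(F)F)c4)c3)cc2-c2ccncc2)c1` share another. How the two cores differ is not broken down here. Within each pair the change is the same: methyl in place of hydrogen on an oxygen on an aromatic ring and (methyl in place of hydrogen on an oxygen on an aromatic ring), at the same kind of place. The step from the first pair is known, a number 1.6 percentage points higher from compound 1 to compound 2 (within the scatter), so the change left this assay essentially unmoved there. Compound 3 stands apart from the first two in this assay, with a number beyond the scatter higher than both. Because of a number 1.6 percentage points higher from compound 1 to compound 2 (within the scatter), the expectation for compound 4 is a step of similar size, a number 1.6 percentage points higher from compound 3 to compound 4 (within the scatter), taken from the value of compound 3. This rests on a single measured instance of the change, so the range is kept wide. Compound 4 is therefore estimated at 28.5%, between 17% and 42%.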

Compound 4, a percentage reported as activity, at one concentration (the size of the read-out at that concentration, not a potency): 57.1%
Beside the measured number, compound 4's estimate is 28.6 percentage points below it; measured number above the stated range.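

In this assay, putting methyl in place of hydrogen on the ring oxygen, which turns 3-chloro-5-hydroxyphenyl into 3-chloro-5-methoxyphenyl, gives a number 30.2 percentage points higher from compound 3 to compound 4 (beyond the scatter) on the core of compound 3, and the two cores clearly do not respond alike: the same change on two cores in this assay, a number 1.6 percentage points higher (within the scatter) from compound 1 to compound 2 and a number 30.2 percentage points higher (beyond the scatter) from compound 3 to compound 4, 28.6 percentage points apart, beyond the scatter of two such steps. A step measured on one core therefore did not carry over to the other in this series, and here the hydroxy form, compound 3, has the stronger effect at the concentration tested. Within the data shown here, this does not show why the two cores part ways, and with only two instances of the change it cannot say which of them a further core would follow.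

The compounds shown leave open how a longer chain on that oxygen, such as ethoxy or propoxy, would fare on each core. They also leave open whether an amine in place of the hydroxy would separate the two cores in the same way.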